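A few compounds are considered here, and "the series" means these few. Any claim that something is new, unique, unknown or untested is made for them only; others in the source may bear on it.

Of the compounds shown here, three that share one core have been measured in an assay on Sf9 cells for inhibition of protein deacetylase HDAC6 (Homo sapiens), read by fluorescence, with a stated time of 40 min, tested at 100 nM; on this read-out higher numbers stand for more inhibition at the one concentration tested (going by the name of the read-out) and lower numbers for less inhibition. Compound 1 `O=C(NO)c1ccc(NCc2nc(-c3ccccc3)nn2-c2ccccc2Cl)cc1` gives 64.6%, compound 2 `O=C(NO)c1ccc(NCc2nc(-c3ccccc3)nn2-c2cccc(Cl)c2)cc1` gives 62.3%, and compound 3 `Cc1ccccc1-c1nc(CNc2ccc(C(=O)NO)cc2)n(-c2ccccc2)n1` gives 53.2%. Compound 3 is the lowest of the three numbers: the gap to compound 1 lies beyond the scatter, whereas the gap to compound 2 lies within it. For the measured compounds named here, the only measured step, a number 2.3 percentage points lower from compound 1 to compound 2 (within the scatter), concerns the group on the aromatic nitrogen and so does not touch the part of the molecule changed next. Compound 4 `O=C(NO)c1ccc(NCc2nc(-c3ccc(C(F)(F)F)cc3)nn2-c2ccccc2)cc1` differs from compound 3 by 4-(trifluoromethyl)phenyl in place of 2-methylphenyl on an aromatic carbon. Going by the values given here, no measured step bears on this exchange; compounds 1 and 2 carry a phenyl group on the same aromatic carbon, but they also differ from compound 3 at the aromatic nitrogen, so their values give only a loose guide. Compound 4 is therefore expected to show a number 3.8 percentage points higher from compound 3 to compound 4 (within the scatter), a step that need not exceed the scatter. Compound 4 is estimated to give about 57%, with a range from 40% to 74% in this assay.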

Compound 4, a percentage reported as inhibition, at one concentration (the size of the read-out at that concentration, not a potency): 41.6%
The estimate for compound 4 lay 15.4 percentage points above the measured number, and the stated range covers the measured number.
By their numbers in this assay, from the lowest: compound 4; then compounds 3, 2 and 1 (each within the scatter of the next, the first and the last beyond it).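

For the compounds shown here, on the aromatic carbon of the five-membered aromatic ring with 3 nitrogen, 4-(trifluoromethyl)phenyl in place of 2-methylphenyl gives a number 11.6 percentage points lower from compound 3 to compound 4 (beyond the scatter) in this assay, so the group at this position can move the read-out, whereas the one earlier step, a number 2.3 percentage points lower from compound 1 to compound 2 (within the scatter), concerned the aromatic nitrogen. The exchange alters both the substituent on the phenyl ring and where it sits, and the entering group is the larger by count of heavy atoms, so this single step cannot separate these changes. No measurement shown here explains the step.

The compounds shown leave open whether 4-methylphenyl or 2-(trifluoromethyl)phenyl on this carbon would read nearer compound 3 or compound 4. They also leave open how a methoxy group or a carboxylic acid on that phenyl ring would fare.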